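The source may hold more compounds than are shown below. What is called first, only, known or untested is meant among the compounds shown, and "the series" means these compounds.

Measured so far:
compound 1 `O=C(O)CC1COc2cc(OCc3cccc(N4CCCCC4)c3)ccc21`, in a functional assay on CHO cells for agonist activity at Free fatty acid receptor 1 (Homo sapiens), read by FLIPR and calcium flux, with a stated time of 90 s, tested at 100 nM; on this read-out lower numbers stand for a weaker effect and higher numbers for a stronger effect at the one concentration tested: 34.7%
compound 2 `O=C(O)CC1COc2cc(OCc3cccc(-n4cccc4)c3)ccc21`, in this assay: 28.6%

Compound 2 stands within the scatter of compound 1, the only other number shown; the step of a number 6.1 percentage points lower from compound 1 to compound 2 (within the scatter) is the sole measured step. Compound 3 `COCc1cc(C)n(-c2cccc(COc3ccc4c(c3)OCC4CC(=O)O)c2)c1C` is not yet measured. Its change from compound 2: 3-(methoxymethyl)-2,5-dimethyl-1H-pyrrol-1-yl in place of 1H-pyrrol-1-yl on an aromatic carbon. For the measured compounds named here, no measured step exchanges an unsubstituted pyrrol-1-yl for a substituted one, so the single measured step is only a loose guide, and it stayed within the scatter. No step beyond the scatter is therefore expected in this assay. For compound 3 the estimate is 34%, range 12% to 58%. The expected step is a number 5.4 percentage points higher from compound 2 to compound 3 (within the scatter).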

Compound 3, a percentage reported as activity, at one concentration (the size of the read-out at that concentration, not a potency): 31.7%
Compound 3: middle estimate off by 2.3 percentage points, on the high side, and the stated range covers the measured number.
By their numbers in this assay, from the lowest: compounds 2, 3 and 1 (each within the scatter of the next).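

At this aromatic carbon, replacing 1H-pyrrol-1-yl with 3-(methoxymethyl)-2,5-dimethyl-1H-pyrrol-1-yl gives a number 3.1 percentage points higher from compound 2 to compound 3 (within the scatter) in this assay, and replacing piperidin-1-yl with the same group gives a number 3 percentage points lower from compound 1 to compound 3 (within the scatter) in the same read-out. Substitution on the pyrrole therefore adds no step beyond the scatter at this position, and all three groups read alike here. Nothing available explains this result. On these data alone, the methoxymethyl and the two methyl groups enter together, so their separate contributions remain open. As far as these compounds go, whether an amine such as piperazin-1-yl or a carboxylic acid here would move the read-out beyond the scatter is also open.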